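The source may hold more compounds than are shown below. What is called first, only, known or untested is meant among the compounds shown, and "the series" means these compounds.

Measured so far in a functional assay on the whole organism with Mus musculus as the target, in the rotarod test; a lower number here means that less compound is needed, a higher number that more compound is needed for the effect:
- compound 1 `COc1cc2c(cc1OC)C(c1ccc(Cl)cc1)=NN=C(S)C2`: 193 umol/kg
- compound 2 `COc1cc2c(cc1OC)C(c1ccccc1)=NN(C)C(=S)C2`: 97.1 umol/kg

These notes follow the series from compound 2, which gives 97.1 umol/kg in this assay. Compound 1 gives 193 umol/kg, and the two values lie within the usual scatter of each other. The two compounds differ in more than one place, so this pair isolates no single structural change and gives no trend.

The next compound is compound 3 `COc1cc2c(cc1OC)C(c1ccc(N)cc1)=NN(C)C(=S)C2`, still to be measured. Its change from compound 2 is amino in place of hydrogen on an aromatic carbon, or phenyl to 4-aminophenyl. Going by the values given here, no measured pair shows this change, so the expectation is a judgement with little support from the data and carries a wide range. A modest step towards less compound needed is expected, and the range also allows for no change beyond the scatter. The expected step is a 2.4-fold lower number from compound 2 to compound 3 (0.39 log units; beyond the scatter). For compound 3 the estimated value is 40 umol/kg, with an expected range of 12 umol/kg to 120 umol/kg.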

Compound 3, dose for half-maximal effect: 130 umol/kg
Beside the measured number, compound 3's estimate is 3.3-fold (0.51 log units) below it; measured number above the stated range.
By their numbers in this assay, from the lowest: compounds 2, 3 and 1 (each within the scatter of the next).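

In this assay, amino in place of hydrogen on an aromatic carbon, para to a large group, gives a 1.3-fold higher number from compound 2 to compound 3 (0.13 log units; within the scatter), so phenyl to 4-aminophenyl leaves the number within the scatter. Going by these compounds alone, this is the first comparison that isolates a single structural change, which the pair of compound 1 and compound 2 could not do, as those two differ in more than one place; at this one position, on this core, the amino group brings no readable step in either direction, though a single pair cannot show whether the position is insensitive to substitution in general. No measurement is available that bears on why the number behaves this way.

Still open, on these data alone, is whether a nitro group, an acetylamino group or a dimethylamino group at the same position would give a step beyond the scatter, or would likewise stay within it. Also open, as far as these compounds go, is whether the amino group would give the same small step if moved to another carbon of the same ring.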